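Fluoro to Amino on the Aryl Ring of Compound 3

The source may hold more compounds than are shown below. What is called first, only, known or untested is meant among the compounds shown, and "the series" means these compounds.

Three compounds share one core and differ only in the aromatic group attached to the carbonyl carbon. In a functional assay on MDA-MB-231 cells (Homo sapiens) for cytotoxicity, read by MTT assay, with a stated time of 48 h (on this read-out higher numbers stand for weaker inhibition and lower numbers for stronger inhibition), compound 1 `O=C(/C=C/c1ccc2c(c1)B(O)OC2)c1cccnc1` gives 11400 nM and compound 2 `O=C(/C=C/c1ccc2c(c1)B(O)OC2)c1ccc(I)cc1` gives 14900 nM; the step of a 1.3-fold higher number from compound 1 to compound 2 (0.12 log units; within the scatter) lies within the scatter. Compound 3 `O=C(/C=C/c1ccc2c(c1)B(O)OC2)c1cccc(F)c1` gives 3000 nM, the lowest of the three numbers, with steps of a 3.8-fold lower number from compound 1 to compound 3 (0.58 log units; beyond the scatter) and a 5.0-fold lower number from compound 2 to compound 3 (0.70 log units; beyond the scatter) setting it apart from both others.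

Compound 4 `Nc1cccc(C(=O)/C=C/c2ccc3c(c2)B(O)OC3)c1` is not yet measured. It differs from compound 3 by amino in place of fluoro on an aromatic carbon, so the 3-fluorophenyl becomes a 3-aminophenyl. Among the measured compounds shown here, none of the measured steps exchanges one small substituent for another on the same ring; each swaps the whole aromatic group, and the two steps that reach compound 3 show modest gains when the 3-fluorophenyl replaces either alternative. For the measured compounds named here, there is therefore no direct precedent for fluoro against amino, and the expectation is a small step, likely no larger than the scatter, from compound 3 to compound 4, expressed as a 1.7-fold higher number from compound 3 to compound 4 (0.22 log units; within the scatter). Compound 4 is estimated at 5000 nM, with a plausible range from 1500 nM to 20000 nM in this assay.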

Compound 4, half-maximal inhibitory concentration: 3200 nM
For compound 4 the middle estimate is 1.6-fold (0.19 log units) above the measured one; low and high end bracket the measured number.
By their numbers in this assay, from the lowest: compounds 3 and 4 (each within the scatter of the next); then compounds 1 and 2 (each within the scatter of the next).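

In this assay, exchanging fluoro for amino on this aromatic carbon, meta to a large group, gives a 1.1-fold higher number from compound 3 to compound 4 (0.03 log units; within the scatter) and so leaves no readable difference, although amino counts as a hydrogen-bond donor and acceptor while fluoro counts as neither. The separation from the other two aromatic groups also survives the exchange, with a 4.7-fold lower number from compound 2 to compound 4 (0.67 log units; beyond the scatter) and a 3.6-fold lower number from compound 1 to compound 4 (0.55 log units; beyond the scatter) as the steps, so among these four compounds the lower numbers are not tied to fluoro alone, as both the 3-fluorophenyl and the 3-aminophenyl reach them. No measurement available here offers an explanation for why these two groups give matching results.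

Still open, going by these compounds, is how far this tolerance extends, since a plain hydrogen, a hydroxyl, a methoxy group, an acetamide or a carboxylic acid in the same place could each match these two results or depart from them. With only fluoro and amino compared directly on the same ring, two matching groups are too few to show a general rule for this position.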